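Swapping the quinazolinyl group on the oxime oxygen

The source may report more compounds than this note shows. Statements on the series, on what has been measured and on what is new or still open speak of the compounds shown alone.

For the measured compounds named here, compound 2, with structure `Cc1cccc2ncnc(O/N=C(\C=C\c3ccccn3)/C=C/c3ccccc3OCc3ccc(Cl)cc3)c12`, stands highest among the two numbers known here: in a functional assay on SMMC-7721 cells (Homo sapiens) for inhibition, read by MTT assay, with a stated time of 72 h, tested at 1 uM (on this read-out higher numbers stand for a stronger effect at the one concentration tested and lower numbers for a weaker effect), compound 2 gives 93.4%. Its nearest neighbour in this assay is compound 1, with structure `Clc1ccc(COc2ccccc2/C=C/C(/C=C/c2ccccn2)=N/Oc2ncnc3cc(Cl)ccc23)c(Cl)c1`, which differs in two places and is weaker beyond the scatter; in this assay compound 1 gives 23.6%.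

Compound 3, with structure `Clc1ccc(COc2ccccc2/C=C/C(/C=C/c2ccccn2)=N/Oc2ncnc3cc(Cl)ccc23)cc1`, has not yet been measured. Compared with compound 2, it carries 7-chloroquinazolin-4-yl in place of 5-methylquinazolin-4-yl on an oxygen. Going by the values given here, no measured pair shows this single change on its own, so the size of the step is uncertain. A drop beyond the scatter is expected rather than a gain, since compound 1, which shares the 7-chloroquinazolin-4-yl group, gives 23.6% in this assay. Compound 3 is therefore estimated to reach 50%, with a likely range from 20% to 85%, which means an expected step of a number 43.4 percentage points lower from compound 2 to compound 3 (beyond the scatter).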

Compound 3, a percentage reported as inhibition, at one concentration (the size of the read-out at that concentration, not a potency): 94%
Beside the measured number, compound 3's estimate is 44 percentage points below it; measured number above the stated range.
By their numbers in this assay, from the lowest: compound 1; then compounds 2 and 3 (each within the scatter of the next).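

In this assay, putting 7-chloroquinazolin-4-yl in place of 5-methylquinazolin-4-yl on an oxygen gives a number 0.6 percentage points higher from compound 2 to compound 3 (within the scatter), so the 7-chloroquinazolin-4-yl group alone does not account for the low number of compound 1. For the compounds shown here, with that group held constant, hydrogen in place of chloro on an aromatic carbon gives a number 70.4 percentage points higher from compound 1 to compound 3 (beyond the scatter), which makes this single chloro the one change that separates a weak compound from a strong one among the compounds that can be compared. Nothing available here explains why removing this chloro has so large an effect.

Each number comes from one concentration, so compound 2 and compound 3 could still differ in the size of their effect at lower concentrations. As far as these compounds go, it also remains open how a fluoro, a methoxy or an amine would behave in place of that chloro.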